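Solubility of compound 4 expected to remain at the limit

A few compounds are considered here, and "the series" means these few. Any claim that something is new, unique, unknown or untested is made for them only; others in the source may bear on it.

Compound 1 `CCN(CCN)c1ccc(Nc2cc(NC3CC3)n3ncc(C#N)c3n2)cc1NC(C)=O` stands at the upper edge of the numbers available here, and only as a limit. In a physicochemical assay for solubility, read by LC-MS, in phosphate buffer, with a stated time of 24 h, at pH 7.4 (on this read-out higher numbers stand for higher solubility and lower numbers for lower solubility), compound 1 gives > 1000000 nM, which is a limit of the assay and not a number. Compound 2 `CC(=O)Nc1cc(Nc2cc(NC3CC3)n3ncc(C#N)c3n2)ccc1N1CC[C@H](N(C)C)C1` also sits at a limit, giving > 800000 nM in this assay. Compound 3 `CC(=O)Nc1cc(Nc2cc(NC3CC3)n3ncc(C#N)c3n2)ccc1N1CCC[C@@H](N(C)C)C1` likewise sits at a limit, giving > 900000 nM in this assay. Because all three values are limits (the limit of > 1000000 nM in this assay, at which 1 of the 3 values shown sits, (the limit of > 800000 nM in this assay, at which 1 of the 3 values shown sits), (the limit of > 900000 nM in this assay, at which 1 of the 3 values shown sits)), the steps a step that the two limits leave unreadable from compound 1 to compound 2 and a step that the two limits leave unreadable from compound 1 to compound 3 cannot be read in size, and the same holds for a step that the two limits leave unreadable from compound 2 to compound 3.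

Compound 4 `CC(=O)Nc1cc(Nc2cc(NC3CC3)n3ncc(C#N)c3n2)ccc1N1CCC[C@H](N)C1` differs from compound 1 by a group of 7 heavy atoms (5 carbon, 2 nitrogen; one six-membered non-aromatic ring with 1 hetero atom) in place of a group of 6 heavy atoms (4 carbon, 2 nitrogen; no ring), on an aromatic carbon. The ring-forming steps from compound 1 to compound 2 and to compound 3 bear on this change, but their size is hidden by the limits, so no direction can be read from them; they only show that every measured compound stays at or beyond the highest reportable value. Compound 4 is therefore expected to behave the same way, with an estimated step of an at least 1.1-fold lower number from compound 1 to compound 4 (0.04 log units; that floor lies within the scatter). The estimate for compound 4 in this assay is 900000 nM, within a range from 300000 nM to 2000000 nM, and most likely the assay will again report only a limit.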

Compound 4, solubility: 704000 nM
For compound 4 the middle estimate is 1.3-fold (0.11 log units) above the measured one, within the range that was stated.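

In this assay, compound 4 is the only compound shown at this position that gives a measured number and not a limit, so 3-aminopiperidin-1-yl, on an aromatic carbon ortho to an acetamido group, offers the first reading that can be set against the other groups there. The comparison yields an at least 1.4-fold lower number from compound 1 to compound 4 (0.15 log units; that floor lies within the scatter), then an at least 1.2-fold lower number from compound 3 to compound 4 (0.10 log units; that floor lies within the scatter), and finally an at least 1.1-fold lower number from compound 2 to compound 4 (0.05 log units; that floor lies within the scatter), so all three steps point the same way but none is shown to lie beyond the scatter. These steps are floors only, because the other compound in each step stands at a limit, as compound 1 does: the limit of > 1000000 nM in this assay, at which 1 of the 4 values shown sits.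

As far as these compounds go, the true size of these three steps stays open, as do the steps among compound 1, compound 2 and compound 3, which cannot be read. Also open, from the compounds shown here alone, is what a morpholine ring or a carboxylic acid on a longer chain would give at this same aromatic carbon, and whether any group there would bring the number clearly down from that of compound 4.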